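Changing the phenyl substituent on a shared core

This account rests on a few compounds, and the source may have more. Where it says the series, first, only, none or still open, it means among the compounds named here.

Of the compounds shown here, three that share one core have been tested in a functional assay, tested at 400 ug/mL; on this read-out higher numbers stand for a stronger effect at the one concentration tested and lower numbers for a weaker effect. Compound 2 `CN(C)c1ccc(C2C(C#N)=C(N)OC(c3c[nH]c4ccccc34)=C2C#N)cc1` gives 26.7%. Compound 3 `Cc1ccccc1C1C(C#N)=C(N)OC(c2c[nH]c3ccccc23)=C1C#N` gives 25.7%, so that a number 1 percentage points lower from compound 2 to compound 3 (within the scatter). Compound 1 `N#CC1=C(N)OC(c2c[nH]c3ccccc23)=C(C#N)C1c1ccccc1F` is recorded as "not active" (no number reported). Among the two numbers shown, compound 3 sits within the scatter of compound 2, and compound 1 provides no number at all. Compound 4 `N#CC1=C(N)OC(c2c[nH]c3ccccc23)=C(C#N)C1c1ccc(F)cc1` differs from compound 3 by 4-fluorophenyl in place of 2-methylphenyl on a saturated ring carbon. Among the compounds with values here, no measured step covers this exact change; the step from compound 2 to compound 3 was within the scatter, and compound 1, which also bears a fluorine, gave no activity. Compound 4 is therefore expected to give 20%, estimated between 0% and 35%. This estimate means an expected step of a number 5.7 percentage points lower from compound 3 to compound 4 (within the scatter), a modest drop, with a real chance of no activity.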

Compound 4, a percentage reported as activity, at one concentration (the size of the read-out at that concentration, not a potency): 26.7%
For compound 4 the middle estimate is 6.7 percentage points below the measured one; the range from low to high includes it.
By their numbers in this assay, from the lowest: compounds 3, 2 and 4 (each within the scatter of the next).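

In this assay, 4-fluorophenyl on the saturated ring carbon fits in as well as the earlier groups: there is a number 1 percentage points higher from compound 3 to compound 4 (within the scatter) and no change at the digits printed from compound 2 to compound 4 (within the scatter). A fluorine on the phenyl group therefore does not by itself end the effect, although compound 1, which also carries one, stands against any simple pattern with "not active" (no number reported). Nothing measured here explains these results. Still open, going by these compounds, is whether the position of the fluorine accounts for compound 1, and whether a carboxylic acid on the phenyl group, or a longer chain in its place, would keep the effect.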